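This account rests on a few compounds, and the source may have more. Where it says the series, first, only, none or still open, it means among the compounds named here.

Measured so far:
- compound 1 `CN(CC1CCN(CCCc2c[nH]c3ccc(-n4cnnc4)cc23)CC1)C(=O)Nc1ccccc1`: in an assay on CHO cells for displacement of a labelled ligand from 5-hydroxytryptamine receptor 1B (Homo sapiens) (on this read-out higher numbers stand for weaker inhibition and lower numbers for stronger inhibition), compound 1 gives 6.2 nM
- compound 2 `O[C@H]1Cc2ccccc2C1NC1CCN(CCCc2c[nH]c3ccc(-n4cnnc4)cc23)CC1`: in this assay compound 2 gives 300 nM

Compound 2 stands at the higher of the two numbers; compound 1 lies well below it, beyond the scatter. Compound 3 `c1ccc(CNCC2CCN(CCCc3c[nH]c4ccc(-n5cnnc5)cc34)CC2)cc1` is compound 2 with (benzylamino)methyl in place of (2-hydroxy-2,3-dihydro-1H-inden-1-yl)amino on a saturated ring carbon. Within the data shown here, no measured pair differs in one place, so the step has no direct precedent. Compound 3 shares with compound 1 a methylene-linked nitrogen on the saturated ring carbon, and compound 1 gives 6.2 nM. The step from compound 2 to compound 3 is therefore expected to lower the number, by a 7.5-fold lower number from compound 2 to compound 3 (0.88 log units; beyond the scatter). Compound 3 is expected at 40 nM, within 8 nM to 200 nM.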

Compound 3, half-maximal inhibitory concentration: 28 nM
Beside the measured number, compound 3's estimate is 1.4-fold (0.15 log units) above it; the measured number falls inside the stated range.
By their numbers in this assay, from the lowest: compound 1; then compound 3; then compound 2.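

In this assay, the group on the saturated ring carbon strongly affects the number: (benzylamino)methyl in place of (2-hydroxy-2,3-dihydro-1H-inden-1-yl)amino gives an 11-fold lower number from compound 2 to compound 3 (1.03 log units; beyond the scatter) as a large step. On the saturated chain carbon bound to that ring carbon, benzylamino in place of methyl(phenylcarbamoyl)amino gives a 4.5-fold higher number from compound 1 to compound 3 (0.65 log units; beyond the scatter) as a modest step. No available evidence gives a reason for either step.

Which part of the exchanged group carries the large step stays open, since the hydroxy group and the five-membered ring leave together. As far as these compounds go, whether dimethylamino on that chain carbon would hold the number also stays open.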